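From Propoxycarbonyl to 2-Methoxyphenyl on the Shared Core

This account rests on a few compounds, and the source may have more. Where it says the series, first, only, none or still open, it means among the compounds named here.

Of the compounds shown here, three have been measured in a functional assay on WI-38 VA13 cells (Homo sapiens) for cytotoxicity; on this read-out lower numbers stand for an effect already at smaller amounts and higher numbers for an effect only at larger amounts of compound. Compound 1 `O=C(Nc1ccc2nc(NC(=O)C3CCCCC3)sc2c1)c1ccccc1C(F)(F)F` gives 0.024 ug/mL, and compound 2 `Cc1ccc(C(=O)Nc2ccc3nc(NC(=O)C4CCCCC4)sc3c2)cc1` gives 5.1 ug/mL; the step of a 210-fold higher number from compound 1 to compound 2 (2.33 log units; beyond the scatter) concerns the group on the carbonyl carbon. Compound 3 `CCCOC(=O)Nc1nc2ccc(NC(=O)c3c(Cl)cccc3Cl)cc2s1` gives 0.0025 ug/mL, the lowest of the three numbers and beyond the scatter from both of the others. Compound 4 `COc1ccccc1Nc1nc2ccc(NC(=O)c3c(Cl)cccc3Cl)cc2s1` has not yet been measured; it differs from compound 3 by 2-methoxyphenyl in place of propoxycarbonyl on a nitrogen on an aromatic ring. For the measured compounds named here, no measured step alters a group on the nitrogen on the aromatic ring, so the single measured step does not bear directly on this change, and the direction remains open. Compound 4 is therefore expected to give 0.02 ug/mL, with a range from 0.002 ug/mL to 0.2 ug/mL, which as an estimate means an 8.0-fold higher number from compound 3 to compound 4 (0.90 log units; beyond the scatter).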

Compound 4, half-maximal effective concentration: > 7.2 ug/mL
Compound 4 ended at the assay's limit; the forecaster's own chance of this, stated with the estimate: 5%; middle value at least 360-fold (2.55 log units) from the limit.
By their numbers in this assay, from the lowest: compound 3; then compound 1; then compound 2. At a limit, above all of these: compound 4.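

In this assay, 2-methoxyphenyl in place of propoxycarbonyl on a nitrogen on an aromatic ring gives an at least 2800-fold higher number from compound 3 to compound 4 (3.45 log units; beyond the scatter). For the compounds shown here, the group on this nitrogen, which no earlier step altered, can therefore decide on its own between one of the lowest numbers and no measurable number. For compound 4 the reading is a limit of the assay, not a number: the limit of > 7.2 ug/mL in this assay, at which 1 of the 4 values shown sits.

Going by these compounds alone, the single swap removes the carbonyl and brings in the aromatic ring together, so the two remain unseparated, and the full size of the step stays open. An acetyl group, a free amine or a plain phenyl on the same nitrogen would bear on that question.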